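The compounds below may be only part of what the source reports. "The series", "measured", "known", "first", "only" and "open" are said of these compounds alone.

Measured so far:
compound 1 `O=c1c(-c2ccc(O)cc2)coc2cc(OCCCCCCCCCO)ccc12`: 700 nM
compound 2 `CCOC(=O)CCCCOc1ccc2c(=O)c(-c3ccc(O)cc3)coc2c1`: 240 nM

In an assay (Cricetulus griseus) for inhibition of aldehyde dehydrogenase, mitochondrial (Homo sapiens) (on this read-out lower numbers stand for stronger inhibition and higher numbers for weaker inhibition), compound 2 gives the lowest of the two numbers; compound 1 sits above it by a 2.9-fold lower number from compound 1 to compound 2 (0.46 log units; beyond the scatter). Compound 3 `O=C(O)CCCCCCCCCCCOc1ccc2c(=O)c(-c3ccc(O)cc3)coc2c1` differs from compound 2 by 7-carboxyheptyl in place of ethoxycarbonyl on a saturated chain carbon, four bonds along the chain from an oxygen on an aromatic ring. For the measured compounds named here, only the step from compound 1 to compound 2 bears on this, and it was modest, so a long chain with a terminal oxygen function again, now acid-terminated, may move the number back toward compound 1. A modest rise is expected, a 2.1-fold higher number from compound 2 to compound 3 (0.32 log units; beyond the scatter), with direction uncertain. Compound 3 is therefore estimated at 500 nM, range 150 nM to 1600 nM.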

Compound 3, half-maximal inhibitory concentration: 130 nM
Beside the measured number, compound 3's estimate is 3.8-fold (0.59 log units) above it, and the stated range ends above it.
By their numbers in this assay, from the lowest: compounds 3 and 2 (each within the scatter of the next); then compound 1.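

In this assay, the long acid-terminated chain stands level with the short ester, with a 1.8-fold lower number from compound 2 to compound 3 (0.27 log units; within the scatter), so 7-carboxyheptyl in place of ethoxycarbonyl is accepted at this position. Replacing the terminal hydroxy with 2-carboxyethyl gives a 5.4-fold lower number from compound 1 to compound 3 (0.73 log units; beyond the scatter), so a long chain alone does not fix the number: what ends it matters in these compounds. No supporting measurement accounts for this difference.

From the compounds shown here alone, whether a shorter chain ending in a carboxylic acid would give a similar number remains open. So does the effect of a terminal amine on the long chain.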